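A few compounds are considered here, and "the series" means these few. Any claim that something is new, unique, unknown or untested is made for them only; others in the source may bear on it.

In a functional assay on KYSE-450 cells (Homo sapiens) for inhibition, read by MTT assay, with a stated time of 48 h (on this read-out higher numbers stand for weaker inhibition and lower numbers for stronger inhibition), compound 1 `COc1ccc(CN(C(=O)C=C(C)C)c2cc(OC)c(OC)c(OC)c2)cc1O` gives 280 nM and compound 2 `COc1ccc(CN(C(=O)CN=[N+]=[N-])c2cc(OC)c(OC)c(OC)c2)cc1O` gives 160 nM, so these two values lie within the usual scatter of each other. Compound 3 `COc1ccc(CN(C(=O)CCCl)c2cc(OC)c(OC)c(OC)c2)cc1O` has chloromethyl in place of azido on a saturated chain carbon bound to a carbonyl carbon. Within the data shown here, only one measured step bears on this part of the structure, a 1.8-fold lower number from compound 1 to compound 2 (0.24 log units; within the scatter), and it stayed within the scatter. No change beyond the scatter is therefore expected in this assay. The expected step is a 1.3-fold higher number from compound 2 to compound 3 (0.10 log units; within the scatter). Compound 3 is estimated at 200 nM, with an expected range of 70 nM to 600 nM.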

Compound 3, half-maximal inhibitory concentration: 110 nM
The estimate for compound 3 lay 1.8-fold (0.26 log units) above the measured number; measured number inside the range.
By their numbers in this assay, from the lowest: compounds 3, 2 and 1 (each within the scatter of the next, the first and the last beyond it).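

Replacing azido with chloromethyl on a saturated chain carbon bound to a carbonyl carbon gives a 1.5-fold lower number from compound 2 to compound 3 (0.16 log units; within the scatter), so these two groups cannot be told apart at this position. Placing 2-chloroethyl instead of 2-methylprop-1-en-1-yl on a carbonyl carbon gives a 2.5-fold lower number from compound 1 to compound 3 (0.41 log units; beyond the scatter), the first step in this small set to pass the scatter. No evidence is available to explain either step. As far as these compounds go, whether an amine or a longer chain at this position would keep this level of inhibition remains open.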